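The source may hold more compounds than are shown below. What is called first, only, known or untested is meant among the compounds shown, and "the series" means these compounds.

Measured in a functional assay on HeLa cells (Homo sapiens) for cytotoxicity, read by cell counting, with a stated time of 4 days; on this read-out higher numbers stand for weaker inhibition and lower numbers for stronger inhibition:
compound 1 `C=C(Br)C(=O)Nc1cccc(/C=C2\SC(=O)N(Cc3ccc(C(F)(F)F)cc3)C2=O)c1` gives 820 nM
compound 2 `C=C(Br)C(=O)Nc1cccc(/C=C2\SC(=O)N(Cc3ccc(Cl)cc3)C2=O)c1` gives 2700 nM
compound 3 `Nc1cccc(/C=C2\SC(=O)N(Cc3ccc(C(F)(F)F)cc3)C2=O)c1` gives only a limit, > 250000 nM

Compound 1 and compound 2 differ by chloro in place of trifluoromethyl on an aromatic carbon, and the step is a 3.3-fold higher number from compound 1 to compound 2 (0.52 log units; beyond the scatter). Compound 3 differs from compound 1 by hydrogen in place of (1-bromoethenyl)carbonyl on a nitrogen on an aromatic ring, and the step is an at least 300-fold higher number from compound 1 to compound 3 (2.48 log units; beyond the scatter). For compound 3 this assay reports a limit and no number, (the limit of > 250000 nM in this assay, at which 1 of the 3 values shown sits).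

Compound 4 `Nc1cccc(/C=C2\SC(=O)N(Cc3ccc(Cl)cc3)C2=O)c1` has not been measured in this assay. It differs from compound 3 by chloro in place of trifluoromethyl on an aromatic carbon, the same change as from compound 1 to compound 2, at a place described in the same words. Beside a 3.3-fold higher number from compound 1 to compound 2 (0.52 log units; beyond the scatter), the step is expected to be a step that the limit leaves unreadable from compound 3 to compound 4. That expectation rests on compound 3 sitting at the limit (the limit of > 250000 nM in this assay, at which 1 of the 3 values shown sits), where a further weakening cannot register as a number. Compound 4 is expected to give 600000 nM, most probably reported again as a limit.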

Compound 4, half-maximal inhibitory concentration: > 250000 nM
Compound 4 gave a limit, no number; the forecaster's own chance of this, stated with the estimate: 90%; the middle value does not contradict the limit.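

On the core of compound 2, hydrogen in place of (1-bromoethenyl)carbonyl on the nitrogen gives an at least 92-fold higher number from compound 2 to compound 4 (1.96 log units; beyond the scatter), so the large loss seen on the core of compound 1 recurs with chloro in place of trifluoromethyl. The two cores can be compared only this far: the same change on two cores in this assay, an at least 300-fold higher number (2.48 log units; beyond the scatter) from compound 1 to compound 3 and an at least 92-fold higher number (1.96 log units; beyond the scatter) from compound 2 to compound 4; the limit leaves it open whether they differ

Compound 4 gives > 250000 nM in this assay, which is a limit and not a number, so the step between compound 3 and compound 4 cannot be read.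

Still open, as far as these compounds go, is how an acetyl or a plain propenoyl group on that nitrogen would read in this assay. Also open, from the compounds shown here alone, is how a methyl or a nitrile in place of chloro would read with the (1-bromoethenyl)carbonyl kept.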